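Working notes: methyl in place of chloro

This account rests on a few compounds, and the source may have more. Where it says the series, first, only, none or still open, it means among the compounds named here.

- Compound 1 `N#Cc1ccc(NC(=O)c2cc(-c3ccncc3)ccc2O)cc1`: 7990 nM
- Compound 2 `O=C(Nc1cc(C(F)(F)F)cc(C(F)(F)F)c1)c1cc(Br)c(-c2ccccc2)cc1O`: 300 nM
- Compound 3 `N#Cc1ccc(NC(=O)c2ccc(Cl)cc2O)cc1`: 1920 nM

In a functional assay on KG-1 cells (Homo sapiens) for cytotoxicity, read by luminescence and CellTiter-Glo, with a stated time of 3 days (a higher number here means a weaker inhibitor, a lower number a stronger inhibitor), compound 3 at 1920 nM stands in the middle of the three measured numbers. Compound 1 is clearly higher at 7990 nM, and compound 2 is clearly lower at 300 nM.

The next compound is compound 4 `Cc1ccc(C(=O)Nc2ccc(C#N)cc2)c(O)c1`, which has methyl in place of chloro on an aromatic carbon, meta to a hydroxy group and para to a large group: methyl in place of chloro on an aromatic carbon.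

For the measured compounds named here, no pair of measured compounds differs in one place only, so the data hold no direct precedent for this exchange. The expectation therefore rests on compound 3 at 1920 nM as the anchor and remains uncertain. In this assay, the expected change is a 1.6-fold higher number from compound 3 to compound 4 (0.19 log units; within the scatter), a small move toward a higher number that probably stays within the scatter. For compound 4, the estimated value is 3000 nM, with an expected range of 1200 nM to 8000 nM.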

Compound 4, half-maximal inhibitory concentration: 2560 nM
The estimate for compound 4 lay 1.2-fold (0.07 log units) above the measured number; measured number inside the range.
By their numbers in this assay, from the lowest: compound 2; then compounds 3 and 4 (each within the scatter of the next); then compound 1.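

In this assay, methyl in place of chloro on an aromatic carbon, meta to a hydroxy group and para to a large group, reads as a 1.3-fold higher number from compound 3 to compound 4 (0.12 log units; within the scatter) and gives the series its first direct comparison at this position. The numbers of the two compounds cannot be told apart, so on this core chloro is not needed to keep the number at this level, and methyl serves equally well here. No supporting measurement bears on this result.

From the compounds shown here alone, whether a methoxy group, an amine or a carboxylic acid on this aromatic carbon would stay within the scatter of compound 3 remains open. Also open, going by these compounds, is whether the same exchange reads alike on a core with trifluoromethyl groups, as in compound 2.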